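Chloro in place of hydrogen on compound 1

The source may hold more compounds than are shown below. What is called first, only, known or untested is meant among the compounds shown, and "the series" means these compounds.

Measured in a functional assay on HL-60 cells (Homo sapiens) for antiproliferative activity, read by MTT assay, with a stated time of 72 h (a higher number here means a weaker inhibitor, a lower number a stronger inhibitor), so far:
compound 1 `NC1=NC2(CCSCC2)N(OCCCOc2ccc(Cl)c(Cl)c2)C(N)=N1` gives 140 nM
compound 2 `NC1=NC2(CCOCC2)N(OCCCOc2ccc(Cl)cc2)C(N)=N1` gives 330 nM
compound 3 `NC1=NC2(CCOCC2)N(OCCCOc2cccc(Cl)c2Cl)C(N)=N1` gives 440 nM

Compound 1 has the lowest number of the three, and its gaps to compound 2 and compound 3 lie beyond the scatter. Compound 4 `NC1=NC2(CCSCC2)N(OCCCOc2cc(Cl)c(Cl)cc2Cl)C(N)=N1` is still unmeasured. It differs from compound 1 by chloro in place of hydrogen on an aromatic carbon and so carries 2,4,5-trichlorophenyl in place of 3,4-dichlorophenyl.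

Within the data shown here, the one measured step that bears on this is a 1.3-fold higher number from compound 2 to compound 3 (0.12 log units; within the scatter) and lies within the scatter. That step, 2,3-dichlorophenyl in place of 4-chlorophenyl, also brings in one more chloro, but on a core that differs from the core of compound 1. No step beyond the scatter is therefore expected in this assay for this change, although a single pair is thin evidence. Compound 4 is estimated at 160 nM and is expected to fall from 60 nM to 400 nM in four of five measurements. The expected change is a 1.1-fold higher number from compound 1 to compound 4 (0.06 log units; within the scatter) and lies within the scatter.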

Compound 4, half-maximal inhibitory concentration: 730 nM
Estimate against measurement, compound 4: 4.6-fold (0.66 log units) below, outside the stated range (above it).
By their numbers in this assay, from the lowest: compound 1; then compounds 2, 3 and 4 (each within the scatter of the next, the first and the last beyond it).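

In this assay, chloro in place of hydrogen on an aromatic carbon, ortho to a large group, is not neutral on the core of compound 1: the change to 2,4,5-trichlorophenyl from 3,4-dichlorophenyl is a 5.2-fold higher number from compound 1 to compound 4 (0.72 log units; beyond the scatter) and marks a loss of activity. The earlier step of a 1.3-fold higher number from compound 2 to compound 3 (0.12 log units; within the scatter) also brought in one more chloro, on a different core and in a different arrangement, and it gave no sign of such a loss. No measurement in hand accounts for the loss at this position.

Still open, on these data alone, is whether the loss belongs to chloro itself or would also follow fluoro, methyl or methoxy at this place. As far as these compounds go, it is also open whether the same added chloro would cost as much on the core of compound 2.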